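The source may hold more compounds than are shown below. What is called first, only, known or untested is meant among the compounds shown, and "the series" means these compounds.

Measured so far in a functional assay on HeLa cells (Homo sapiens) for inhibition, read by MTT assay, with a stated time of 48 h; a higher number here means a weaker inhibitor, a lower number a stronger inhibitor

Compound 1 `CS(=O)(=O)c1ccc(-c2nc3ccccn3c2Sc2ccccc2)cc1` gives 70600 nM
Compound 2 `Cc1ccc(-c2nc3ccccn3c2Sc2ccccc2)cc1` gives 86700 nM
Compound 3 `Cc1ccc2nc(-c3ccc(Cl)cc3)c(Sc3ccccc3)n2c1` gives 79900 nM

Compound 3 at 79900 nM sits among the other two, with its gaps to both lying within the usual scatter. Compound 4 `Clc1ccc(-c2nc3ccccn3c2Sc2ccccc2)cc1` differs from it by a single change, (hydrogen in place of methyl on an aromatic carbon), hydrogen in place of methyl on an aromatic carbon. Going by the values given here, no measured step touches this methyl. Among the compounds with values here, the only measured step, a 1.2-fold higher number from compound 1 to compound 2 (0.09 log units; within the scatter), is a different swap and lies within the scatter. All three values also lie close together, so no step beyond the scatter is expected in this assay. The expected step is a 1.1-fold lower number from compound 3 to compound 4 (0.03 log units; within the scatter) and should stay within the scatter. For compound 4 the estimate is 75000 nM, with an expected range from 42000 nM to 130000 nM.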

Compound 4, half-maximal inhibitory concentration: 62000 nM
Estimate against measurement, compound 4: 1.2-fold (0.08 log units) above; the range from low to high includes it.
By their numbers in this assay, from the lowest: compounds 4, 1, 3 and 2 (each within the scatter of the next).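

In this assay, hydrogen in place of methyl on the six-membered aromatic ring with 1 nitrogen gives a 1.3-fold lower number from compound 3 to compound 4 (0.11 log units; within the scatter), so losing this methyl brings no difference that can be told from the scatter. Chloro in place of methyl gives a 1.4-fold lower number from compound 2 to compound 4 (0.15 log units; within the scatter), and chloro in place of methylsulfonyl gives a 1.1-fold lower number from compound 1 to compound 4 (0.06 log units; within the scatter), so on that other aromatic carbon these three groups cannot be told apart either. No outside evidence bears on these results. Still open, as far as these compounds go, is whether an amine or a carboxylic acid at either place would give a step beyond the scatter.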